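Anilide variation on the shared core: cytotoxicity working notes

A few compounds are considered here, and "the series" means these few. Any claim that something is new, unique, unknown or untested is made for them only; others in the source may bear on it.

compound 1 `O=C(Nc1ccc(Br)cc1)c1c(NO)cc(-c2ccccc2)oc1=O` — > 20000 nM (a limit of the assay)
compound 2 `COc1ccc(NC(=O)c2c(NO)cc(-c3ccccc3)oc2=O)cc1` — > 20000 nM (a limit of the assay)

In an ADME assay on Huh-7 cells (Homo sapiens) for cytotoxicity, read by a luciferase reporter and WST assay, with a stated time of 3 days (on this read-out higher numbers stand for lower toxicity in this test and lower numbers for higher toxicity in this test), compound 1 gives > 20000 nM, which is a limit of the assay and not a number. Compound 2 gives > 20000 nM in this assay, again a limit. Among the measured compounds shown here, the only measured step, a step that the two limits leave unreadable from compound 1 to compound 2, is therefore unreadable. Compound 2 stands at the limit of this assay, as does compound 1, since both values sit at the limit of > 20000 nM in this assay, at which 2 of the 2 values shown sit.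

Compound 3 `Cc1ccccc1NC(=O)c1c(NO)cc(-c2ccccc2)oc1=O` differs from compound 2 by 2-methylphenyl in place of 4-methoxyphenyl on an amide-type nitrogen. For the measured compounds named here, no measured step bears directly on this change, and the one step on record is unreadable, so no direction can be taken from it. The expectation is that compound 3 again reaches the limit in this assay, estimated at 30000 nM with a range of 15000 nM to 100000 nM. The implied step that the limit leaves unreadable from compound 2 to compound 3 is expected to stay within the scatter, with a limit rather than a number the most likely outcome.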

Compound 3, half-maximal cytotoxic concentration: > 20000 nM
Compound 3: a limit, no number; the forecaster's own chance of this, stated with the estimate: 80%; the middle value lies beyond the limit too.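

Compound 1, compound 2 and compound 3 all stand at a limit of this assay, not at a number, so no step among them can be read: the limit of > 20000 nM in this assay, at which 3 of the 3 values shown sit.

The compounds shown leave open whether any change on the amide-type nitrogen alters cytotoxicity in this assay.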